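Two Added Fluorines on the Phenyl Ring of Compound 1

The source may hold more compounds than are shown below. What is called first, only, known or untested is meant among the compounds shown, and "the series" means these compounds.

Compound 1 `CCc1nc(Cl)c2n1CCN([C@@H](C(=O)NC)c1ccccc1)[C@H]2CCc1cccc(C(F)(F)F)c1` has been tested in a functional assay on CHO cells for antagonist activity at Orexin receptor type 2 (Homo sapiens), read by FLIPR and calcium flux (a higher number here means a weaker inhibitor, a lower number a stronger inhibitor), where compound 1 gives 10 nM. It stands at the highest of the two numbers measured, though only by the step of a 1.1-fold lower number from compound 1 to compound 2 (0.05 log units; within the scatter), so it and compound 2 `CCc1nc(Cl)c2n1CCN([C@@H](C(=O)NC)c1ccccc1)[C@H]2COc1ccc(C(F)(F)F)cc1`, which gives 9 nM in this assay, cannot be told apart. The unmeasured compound 3 `CCc1nc(Cl)c2n1CCN([C@@H](C(=O)NC)c1ccccc1)[C@H]2CCc1ccc(C(F)(F)F)c(F)c1F` differs from compound 1 in one place: 2,3-difluoro-4-(trifluoromethyl)phenyl in place of 3-(trifluoromethyl)phenyl on a saturated chain carbon, two bonds along the chain from a saturated ring carbon. Among the compounds with values here, no measured step adds fluorine to this phenyl ring; the one comparison available swapped the whole pendant group and its link and stayed within the scatter, which suggests this position accepts change without a large shift. The step of a 1.2-fold higher number from compound 1 to compound 3 (0.08 log units; within the scatter) is expected to be small, likely within the scatter. Compound 3 is therefore estimated at 12 nM, with a range from 4 nM to 40 nM.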

Compound 3, half-maximal inhibitory concentration: 14 nM
The estimate for compound 3 lay 1.2-fold (0.07 log units) below the measured number; the measured number falls inside the stated range.
By their numbers in this assay, from the lowest: compounds 2, 1 and 3 (each within the scatter of the next).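

Within the data shown here, this is the first comparison that changes the phenyl ring itself while keeping the chain that carries it. In this assay, replacing 3-(trifluoromethyl)phenyl with 2,3-difluoro-4-(trifluoromethyl)phenyl gives a 1.4-fold higher number from compound 1 to compound 3 (0.15 log units; within the scatter), so the two compounds cannot be told apart, and this position accepts a ring bearing two added fluorines and a differently placed trifluoromethyl group without a shift beyond the scatter. No measurement at hand offers an explanation for this result.

The two parts of the change remain unseparated, so the contribution of the added fluorines cannot be distinguished from that of the trifluoromethyl group's new place on the ring. As far as these compounds go, whether this ring would also accept a group of another kind, such as an amine or a carboxylic acid, remains open.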